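The source may hold more compounds than are shown below. What is called first, only, known or untested is meant among the compounds shown, and "the series" means these compounds.

Measured compounds in an assay on isolated protein for inhibition of Alpha glucosidase (Homo sapiens), with stated times of 5 min and 15 min, tested at 50 uM; on this read-out lower numbers stand for less inhibition and higher numbers for more inhibition at the one concentration tested (going by the name of the read-out):
- compound 1 `O=C1/C(=C/c2ccccc2)CCC/C1=C\c1ccc(O)cc1`: 53%
- compound 2 `O=C(/C=C(O)/C=C/c1ccc(O)c(O)c1)c1ccccc1O`: 93.6%
- compound 3 `COc1cccc(/C=C2\CCC/C(=C\c3ccccc3)C2=O)c1OC`: 31.8%

Among these three numbers compound 1 stands second highest. Its nearest neighbour is compound 3, whose inhibition lies lower by a gap beyond the scatter, and the furthest is compound 2, whose inhibition lies higher by a gap also beyond the scatter. Among the compounds with values here, no step between two of the measured compounds differs in a single place, so nothing about any one change has been measured directly.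

The unmeasured compound 4 `O=C1/C(=C/c2ccccc2)CCC/C1=C\c1cccc(Br)c1` differs from compound 1 in one place: 3-bromophenyl in place of 4-hydroxyphenyl on a double-bonded chain carbon bound to a double-bonded ring carbon. The compounds with a free phenolic hydroxyl, compound 2 and compound 1, show the two higher inhibitions here, while compound 3, carrying only methoxy groups, shows the lowest; this pattern rests on three compounds only. On that basis the step from compound 1 to compound 4 is expected to lower the inhibition by a moderate amount, beyond the scatter, in the reading a number 18 percentage points lower from compound 1 to compound 4 (beyond the scatter). Compound 4 is therefore estimated at 35%, within the range 15% to 58%.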

Compound 4, a percentage reported as inhibition, at one concentration (the size of the read-out at that concentration, not a potency): 27.2%
Beside the measured number, compound 4's estimate is 7.8 percentage points above it; low and high end bracket the measured number.
By their numbers in this assay, from the lowest: compounds 4 and 3 (each within the scatter of the next); then compound 1; then compound 2.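

In this assay, the exchange of 4-hydroxyphenyl for 3-bromophenyl on a double-bonded chain carbon bound to a double-bonded ring carbon gives a number 25.8 percentage points lower from compound 1 to compound 4 (beyond the scatter). Within the data shown here, this is a change at a single place on the core of compound 1, so it shows directly what the earlier compounds could only hint at: inhibition at this place depends on the group carried there. Nothing measured here explains the drop.

The step removes the hydroxyl, introduces the bromine and moves the substituent on the ring all at once, so the share of each cannot be read from it. As far as these compounds go, what an unsubstituted phenyl at this place would give stays open, as does the effect of an amine or a carboxylic acid in place of the hydroxyl of compound 1.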